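A few compounds are considered here, and "the series" means these few. Any claim that something is new, unique, unknown or untested is made for them only; others in the source may bear on it.

Compound 2 `COc1ccc(C2CC(c3cccc([N+](=O)[O-])c3)=NN2C(C)=O)cc1` gives 6650 nM in a functional assay on IMR-32 cells (Homo sapiens) for cytotoxicity, read by sulforhodamine B assay, with a stated time of 48 h (on this read-out lower numbers stand for stronger inhibition and higher numbers for weaker inhibition), and compound 1 `CC(=O)N1N=C(c2cccc([N+](=O)[O-])c2)CC1c1ccccc1` gives 7890 nM there. The difference between them, (hydrogen in place of methoxy on an aromatic carbon), produced a 1.2-fold higher number from compound 2 to compound 1 (0.07 log units; within the scatter). Compound 3 `COc1cc(C2CC(c3ccco3)=NN2C(C)=O)cc(OC)c1OC` gives 9870 nM in this assay; the difference between the cores of compound 3 and compound 2 is not broken down here. Compound 4 `COc1ccc(C2CC(c3ccco3)=NN2C(C)=O)cc1OC` carries the same kind of change, (hydrogen in place of methoxy on an aromatic carbon), yet the place differs: ortho to a methoxy group, meta to a large group and meta to a methoxy group, rather than para to a large group. A small step is expected here, a 1.1-fold higher number from compound 3 to compound 4 (0.05 log units; within the scatter), resting on the within-scatter size of a 1.2-fold higher number from compound 2 to compound 1 (0.07 log units; within the scatter). Compound 4 is therefore expected to give about 11000 nM in this assay, most likely between 5500 nM and 22000 nM.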

Compound 4, half-maximal inhibitory concentration: 11200 nM
Compound 4: the middle estimate sits 1.0-fold (0.01 log units) below what was measured; low and high end bracket the measured number.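

In this assay, hydrogen in place of methoxy gives a 1.1-fold higher number from compound 3 to compound 4 (0.05 log units; within the scatter). Set beside the earlier step, the change carries from one core to the other with no readable difference: the same change on two cores in this assay, a 1.2-fold higher number (0.07 log units; within the scatter) from compound 2 to compound 1 and a 1.1-fold higher number (0.05 log units; within the scatter) from compound 3 to compound 4, 1.0-fold (0.02 log units) apart, within the scatter of two such steps. For the compounds shown here, this shows only that the swap stays within the scatter on both cores, at two different places on the ring; it gives no direction for the change and does not show that methoxy is without effect on other cores or at other places.

Open, as far as these compounds go, is whether a different group at these places, such as a hydroxyl, an amine or a carboxylic acid, would move the number beyond the scatter. From the compounds shown here alone, a longer alkoxy chain in place of methoxy is also open.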